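Removing a Protecting Group from a Macrocyclic Lactam

This account rests on a few compounds, and the source may have more. Where it says the series, first, only, none or still open, it means among the compounds named here.

Measured compounds:
Compound 1, `C/C1=C/C=C/C(=O)N[C@@H](C=O)C/C(C)=C/COCC/C=C/C(=O)C1`, gives 10900 nM in a functional assay on LNCaP cells (Homo sapiens) for antiproliferative activity, read by WST assay, with a stated time of 3 days; a lower number here means a stronger inhibitor, a higher number a weaker inhibitor.
Compound 2, `COc1ccc(COC[C@H]2C/C(C)=C/COCC/C=C/C(=O)C/C(C)=C\C=C\C(=O)N2)cc1`, gives 6260 nM in this assay.

Among the compounds with values here, only two compounds have been measured, and compound 2 cannot be separated from compound 1 on these numbers: the step of a 1.7-fold lower number from compound 1 to compound 2 (0.24 log units; within the scatter) lies within the scatter, so the two are, for practical purposes, indistinguishable in potency.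

Compound 3, `C/C1=C/C=C/C(=O)N[C@@H](CO)C/C(C)=C/COCC/C=C/C(=O)C1`, is the next compound. It differs from compound 2 in one place: hydrogen in place of 4-methoxybenzyl on an oxygen on a saturated carbon. In other words, the (4-methoxybenzyl)oxy group becomes a plain hydroxy group, and the ((4-methoxybenzyl)oxy)methyl arm becomes a hydroxymethyl arm, while the shared core is untouched.

Within the data shown here, no measured step addresses this exact change. Among the measured compounds shown here, the single step that comes close, a 1.7-fold lower number from compound 1 to compound 2 (0.24 log units; within the scatter), compares formyl with the protected arm and was within the scatter, giving no direction to build on. The expectation is therefore a step of a 1.3-fold higher number from compound 2 to compound 3 (0.11 log units; within the scatter), that is, no change beyond the scatter. Compound 3 is estimated at 8000 nM, in the range 3000 nM to 25000 nM.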

Compound 3, half-maximal inhibitory concentration: > 12500 nM
Compound 3 ended at the assay's limit; the forecaster's own chance of this, stated with the estimate: 5%; middle value at least 1.5-fold (0.19 log units) from the limit.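

Compound 3 ended at a limit of the assay, so it has no exact number: the limit of > 12500 nM in this assay, at which 1 of the 3 values shown sits. Hydrogen in place of 4-methoxybenzyl gives an at least 1.9-fold higher number from compound 2 to compound 3 (0.30 log units; that floor lies within the scatter), so the true gap may be larger, but this floor alone shows no change beyond the scatter. Hydroxymethyl in place of formyl on the saturated ring carbon gives an at least 1.1-fold higher number from compound 1 to compound 3 (0.05 log units; that floor lies within the scatter), and together these two floors add something the earlier comparison could not show: in this assay, the free hydroxy group gives no sign of a lower number than either the formyl group or the protected arm.

Going by these compounds, how far compound 3 really lies from compound 1 and compound 2 remains open, as only floors are known for both steps. Also open, on these data alone, is whether an amine, a carboxylic acid or a longer chain ending in a hydroxy group at this position would give a number clearly lower than those seen here.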